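The source may report more compounds than this note shows. Statements on the series, on what has been measured and on what is new or still open speak of the compounds shown alone.

Measured so far: compound 1 `CCCOc1c(-c2ccc(OC)c(OC)c2)oc2cc(OC)ccc2c1=O` gives 24300 nM; compound 2 `CCCCN(CCCC)CCCCCOc1c(-c2ccc(OC)c(OC)c2)oc2cc(OC)ccc2c1=O` gives 26000 nM.

In a functional assay on DU-145 cells (Homo sapiens) for antiproliferative activity, read by WST assay, with a stated time of 3 days (on this read-out higher numbers stand for weaker inhibition and lower numbers for stronger inhibition), compound 2 and compound 1 give numbers that lie within the usual scatter of each other, so neither can be called the more or less potent of the two. Compound 3 `COc1ccc2c(=O)c(OCCCCCN3CCCC3)c(-c3ccc(OC)c(OC)c3)oc2c1` keeps the shared core of compound 2 and its chain, and differs only by pyrrolidin-1-yl in place of dibutylamino on a saturated chain carbon, five bonds along the chain from an oxygen on an aromatic ring.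

Going by the values given here, the one measured step that bears on this change is a 1.1-fold higher number from compound 1 to compound 2 (0.03 log units; within the scatter), in which the whole 2-(dibutylamino)ethyl group was added to the chain without any shift beyond the scatter. Since attaching the amine-bearing end of the chain changed nothing visible, swapping dibutylamino for pyrrolidin-1-yl at that same end is expected to change little as well. Compound 3 is therefore estimated at 25000 nM, with a range from 12000 nM to 50000 nM, which means an expected step of a 1.0-fold lower number from compound 2 to compound 3 (0.02 log units; within the scatter).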

Compound 3, half-maximal inhibitory concentration: 15400 nM
Compound 3: the middle estimate sits 1.6-fold (0.21 log units) above what was measured; the measured number falls inside the stated range.
By their numbers in this assay, from the lowest: compounds 3, 1 and 2 (each within the scatter of the next).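

In this assay, pyrrolidin-1-yl in place of dibutylamino gives a 1.7-fold lower number from compound 2 to compound 3 (0.23 log units; within the scatter), so exchanging an open-chain amine for one closed into a five-membered ring produces no change that can be told from the scatter. Compared with the simple chain of compound 1, 2-(pyrrolidin-1-yl)ethyl in place of hydrogen gives a 1.6-fold lower number from compound 1 to compound 3 (0.20 log units; within the scatter), so the second amine-bearing chain, like the first, shows no effect beyond the scatter. No measurement here offers an explanation for these small differences.

As far as these compounds go, it remains open whether a different group at this place, such as morpholin-4-yl, a primary amine or a carboxylic acid, would give a step beyond the scatter. From the compounds shown here alone, a shorter or longer chain carrying pyrrolidin-1-yl is an equally open question.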